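Ethoxy for fluoro on the carboxylic acid core

This account rests on a few compounds, and the source may have more. Where it says the series, first, only, none or still open, it means among the compounds named here.

In a functional assay on Hep 3B2 cells (Homo sapiens) for antiproliferative activity, read by MTT assay, with a stated time of 24 h, tested at 0.41 ug/mL (a lower number here means a weaker effect, a higher number a stronger effect of the compound at the concentration tested), compound 3 `Cc1c(C(=O)Nc2c(F)cc(-c3cccc(F)c3)cc2F)nc2ccc(F)cc2c1C(=O)O` gives 1.06%. Among the three measured compounds that number stands second highest. The nearest is compound 1 `CCOc1ccc2nc(C(=O)Nc3c(F)cc(-c4cccc(F)c4)cc3F)c(C)c(O)c2c1`, which gives 0.26%, within the scatter of compound 3. The furthest is compound 2 `Cc1ccc2nc(C(=O)Nc3c(F)cc(-c4cccc(F)c4)cc3F)c(C)c(C(=O)O)c2c1`, which gives 15.2%, beyond the scatter. Among the compounds with values here, the only measured exchange at one place is a number 14.1 percentage points lower from compound 2 to compound 3 (beyond the scatter), a fluoro in place of a methyl on an aromatic carbon.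

Compound 4 `CCOc1ccc2nc(C(=O)Nc3c(F)cc(-c4cccc(F)c4)cc3F)c(C)c(C(=O)O)c2c1` is not yet measured. It differs from compound 3 in one place: ethoxy in place of fluoro on an aromatic carbon. The step from compound 2 to compound 3 bears on it, as it concerns the same kind of exchange at an aromatic carbon of the shared core, and it was modest; compound 4 removes the fluoro again, but puts an ethoxy rather than a methyl in its place, so that step sets only the scale. Compound 1 carries the same ethoxy with a hydroxy instead of the carboxylic acid, and compound 1 gives 0.26%, so no step can be read from it. A modest rise, a number 5.9 percentage points higher from compound 3 to compound 4 (within the scatter), is expected, not reaching the number of compound 2. Compound 4 is estimated at 7%, with a range from 0% to 18%.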

Compound 4, a percentage reported as inhibition, at one concentration (the size of the read-out at that concentration, not a potency): 5.34%
The estimate for compound 4 lay 1.7 percentage points above the measured number; measured number inside the range.
By their numbers in this assay, from the lowest: compounds 1, 3, 4 and 2 (each within the scatter of the next, the first and the last beyond it).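

In this assay the ethoxy on this aromatic carbon, meta to a fused ring and para to a fused ring, cannot be told apart from either smaller group: with ethoxy in place of fluoro there is a number 4.3 percentage points higher from compound 3 to compound 4 (within the scatter) and with ethoxy in place of methyl there is a number 9.9 percentage points lower from compound 2 to compound 4 (within the scatter) in the same read-out. The only gap beyond the scatter at this place therefore remains the one between methyl and fluoro, a number 14.1 percentage points lower from compound 2 to compound 3 (beyond the scatter) and ethoxy falls on neither side of it. Within the data shown here, with the ethoxy held constant, carboxy in place of hydroxy gives a number 5.1 percentage points higher from compound 1 to compound 4 (within the scatter) so that exchange, now readable for the first time, shows no separation either.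

On these data alone, whether a propoxy chain, an amine or a chloro group at this aromatic carbon would move the number clear of the scatter remains open, as does whether the exchange of carboxy and hydroxy would read the same with methyl or fluoro on the shared core. Nothing measured here offers a reason for any of these steps.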